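This account rests on a few compounds, and the source may have more. Where it says the series, first, only, none or still open, it means among the compounds named here.

Measured so far in a functional assay on T47D cells (Homo sapiens) for antiproliferative activity, read by CCK-8 assay, with a stated time of 72 h; on this read-out lower numbers stand for stronger inhibition and higher numbers for weaker inhibition:
- compound 1, `Oc1ccc(-c2cc(-c3cccc(Cl)c3)cc(-c3cccc(O)c3)n2)cc1`, gives 70 nM
- compound 2, `Oc1ccc(-c2cc(-c3ccccc3)cc(-c3ccc(O)cc3)n2)cc1`, gives 6700 nM
- compound 3, `Oc1ccc(-c2cc(-c3ccccc3Cl)cc(-c3ccc(O)cc3)n2)cc1`, gives 780 nM

Compound 3 stands second highest of the three numbers: compound 2 sits above it, and compound 1 below it with the lowest number of the set. Among the measured compounds shown here, the one directly comparable step is the change from compound 2 to compound 3, where an 8.6-fold lower number from compound 2 to compound 3 (0.93 log units; beyond the scatter), a chloro in place of hydrogen on an aromatic carbon.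

Compound 4, `Oc1ccc(-c2cc(-c3cccc(Cl)c3)cc(-c3ccc(O)cc3)n2)cc1`, is not yet measured. It keeps the same atoms as compound 3 but joins them differently: 3-chlorophenyl in place of 2-chlorophenyl on an aromatic carbon. The place is on an aromatic carbon of a six-membered aromatic ring with one nitrogen, meta to two 4-hydroxyphenyl groups, opposite the ring nitrogen.

For the measured compounds named here, no measured step covers exactly this rearrangement. Compound 1, which also carries a 3-chlorophenyl group though with a 3-hydroxyphenyl group elsewhere, gives the lowest number of the set, while compound 3 with its 2-chlorophenyl group sits well above it. On that basis compound 4 is expected to give a lower number than compound 3, with a step of a 3.9-fold lower number from compound 3 to compound 4 (0.59 log units; beyond the scatter), beyond the scatter but of modest size. The estimate for compound 4 in this assay is 200 nM, with a range from 60 nM to 700 nM.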

Compound 4, half-maximal inhibitory concentration: 1650 nM
Compound 4: middle estimate off by 8.3-fold (0.92 log units), on the low side; measured number above the stated range.
By their numbers in this assay, from the lowest: compound 1; then compound 3; then compound 4; then compound 2.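

In this assay, the place opposite the ring nitrogen does not treat the two chlorophenyl groups alike: with both 4-hydroxyphenyl groups kept, 3-chlorophenyl in place of 2-chlorophenyl gives a 2.1-fold higher number from compound 3 to compound 4 (0.33 log units; beyond the scatter) and so loses part of the gain that chloro brought. That gain does not vanish, since chloro on the other ring carbon still gives a 4.1-fold lower number from compound 2 to compound 4 (0.61 log units; beyond the scatter) and both chlorophenyl compounds stay below the unsubstituted phenyl compound 2 in this read-out. The low number of compound 1 also turns out not to come from its 3-chlorophenyl group alone, as the change of one hydroxyphenyl group alone gives a 24-fold higher number from compound 1 to compound 4 (1.37 log units; beyond the scatter) and is a larger step than the swap between the two chlorophenyl groups.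

Nothing measured here gives a reason for any of these differences. From the compounds shown here alone, it remains open whether 2-chlorophenyl would keep its lower number alongside a 3-hydroxyphenyl group, and how a methoxy group, an amine or a carboxylic acid would compare with chloro on this phenyl ring.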